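Branching the Amide Chain of an Adenosine Receptor Ligand

The source may report more compounds than this note shows. Statements on the series, on what has been measured and on what is new or still open speak of the compounds shown alone.

compound 1 `Nc1ncc(-c2ccc(F)cc2)c(-c2ccccc2)n1`: > 80%
compound 2 `CCCC(=O)Nc1ncc(-c2cccc(Cl)c2)c(-c2ccccc2)n1`: > 80%

In an assay on CHO cells for displacement of a labelled ligand from adenosine receptor A1 (Homo sapiens), read by scintillation counting, with a stated time of 1 h, tested at 1 uM (a higher number here means more inhibition at the concentration tested (going by the name of the read-out), a lower number less inhibition), compound 1 gives > 80%, which is a limit of the assay rather than a number. Compound 2 reaches > 80%, again a limit. Going by the values given here, the only thing the two values show together is the limit of > 80% in this assay, at which 2 of the 2 values shown sit. Compound 3 `CC(C)CC(=O)Nc1ncc(-c2cccc(Cl)c2)c(-c2ccccc2)n1` differs from compound 2 by methyl in place of hydrogen on a saturated chain carbon bound to two saturated chain carbons. Among the compounds with values here, with no measured step between compounds and both known values sitting at the limit, no change beyond the usual scatter is expected here. The step that the limit leaves unreadable from compound 2 to compound 3 is thus expected to be small. Compound 3 is estimated to reach 85%, between 70% and 98%, most likely reported again only as a limit.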

Compound 3, a percentage reported as inhibition, at one concentration (the size of the read-out at that concentration, not a potency): 56%
Compound 3: middle estimate off by 29 percentage points, on the high side; the measured number lies below the stated range.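

Methyl in place of hydrogen on a saturated chain carbon bound to two saturated chain carbons, which turns propylcarbonyl into isobutylcarbonyl, gives in this assay a number at least 24 percentage points lower from compound 2 to compound 3 (beyond the scatter). This chain is therefore not indifferent to change, as a single methyl brings the value down from the limit. The full size of the step stays unknown because compound 2 carries only a limit: the limit of > 80% in this assay, at which 2 of the 3 values shown sit.

Going by these compounds, it remains open whether a longer unbranched chain would lower the number as well, so branching cannot yet be told apart from added length. On these data alone, how an amine or a carboxylic acid on this chain would read is also open.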